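The Same Substituent Swap, Made Twice

The source may hold more compounds than are shown below. What is called first, only, known or untested is meant among the compounds shown, and "the series" means these compounds.

Measured compounds:
compound 1, `CCCCc1ccc2[nH]c(-c3ccc(OC)cc3)c(C=O)c2c1`, 6.7 nM
compound 2, `CCCCc1ccc2[nH]c(-c3ccc(C(F)(F)F)cc3)c(C=O)c2c1`, 33 nM
compound 3, `CCCCc1ccc2[nH]c(-c3ccc(OC)cc3)c(/C=N/NC(=O)c3ccncc3)c2c1`, 29 nM

In a functional assay on MDA-MB-231 cells (Homo sapiens) for antiproliferative activity, with a stated time of 4 days (a higher number here means a weaker inhibitor, a lower number a stronger inhibitor), compound 1 gives 6.7 nM, compound 2 gives 33 nM and compound 3 gives 29 nM. Compound 2 is obtained from compound 1 by trifluoromethyl in place of methoxy on an aromatic carbon; this change produced a 4.9-fold higher number from compound 1 to compound 2 (0.69 log units; beyond the scatter). Compound 3 carries the same methoxyphenyl as compound 1 on a different core; the difference between the two cores is not broken down here, and its value stands near that of compound 2.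

Compound 4, `CCCCc1ccc2[nH]c(-c3ccc(C(F)(F)F)cc3)c(/C=N/NC(=O)c3ccncc3)c2c1`, is not yet measured. It differs from compound 3 by trifluoromethyl in place of methoxy on an aromatic carbon. The place is described in exactly the same words as for the pair of compound 1 and compound 2, so this is the same change made a second time, now on the core of compound 3.

Compound 4 is expected to give a 4.1-fold higher number from compound 3 to compound 4 (0.62 log units; beyond the scatter) in this assay, because the matching change gave a 4.9-fold higher number from compound 1 to compound 2 (0.69 log units; beyond the scatter). Compound 4 is therefore estimated at 120 nM, with a range from 40 nM to 400 nM.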

Compound 4, half-maximal inhibitory concentration: 94 nM
Beside the measured number, compound 4's estimate is 1.3-fold (0.11 log units) above it, within the range that was stated.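

Carried to the second core, trifluoromethyl in place of methoxy again gave a weaker inhibitor in this assay, with a 3.2-fold higher number from compound 3 to compound 4 (0.51 log units; beyond the scatter), and the two steps do not differ by more than the scatter allows: the same change on two cores in this assay, a 4.9-fold higher number (0.69 log units; beyond the scatter) from compound 1 to compound 2 and a 3.2-fold higher number (0.51 log units; beyond the scatter) from compound 3 to compound 4, 1.5-fold (0.18 log units) apart, within the scatter of two such steps

With the 4-(trifluoromethyl)phenyl held fixed, the change of core also moves the value, with a 2.8-fold higher number from compound 2 to compound 4 (0.45 log units; beyond the scatter), so the swap and the core difference both leave a mark on compound 4. This shows that in this series the size of the swap carried over from one core to the other, but it rests on just two pairs and one assay, so it gives no general rule for other cores and does not explain why the swap has this effect.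

The compounds shown leave open how an amine or a carboxylic acid would behave in place of methoxy on the same aromatic carbon. They also leave open whether the step would hold with a longer chain in place of butyl.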